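Semicarbazone series on a shared azaindole ether core

A few compounds are considered here, and "the series" means these few. Any claim that something is new, unique, unknown or untested is made for them only; others in the source may bear on it.

Measured so far:
- compound 1, `O=C(N/N=C/c1cccc([N+](=O)[O-])c1)Nc1ccc(Oc2ccnc3[nH]ccc23)c(F)c1`: "not active" (no number reported)
- compound 2, `O=C(N/N=C/c1ccc(F)cc1Cl)Nc1ccc(Oc2ccnc3[nH]ccc23)c(F)c1`: 7610 nM
- compound 3, `COc1cc(/C=N/NC(=O)Nc2ccc(Oc3ccnc4[nH]ccc34)c(F)c2)cc(OC)c1OC`: 21900 nM

The three measured compounds share one core and differ only in the aryl group on the carbon with a double bond to nitrogen. In a functional assay on MCF7 cells (Homo sapiens) for antiproliferative activity, read by MTT assay, with a stated time of 72 h (on this read-out higher numbers stand for weaker inhibition and lower numbers for stronger inhibition), compound 2 gives 7610 nM, and compound 3 gives 21900 nM. In this assay compound 1 is recorded as "not active" (no number reported), so no single number fixes where compound 1 stands; all that can be said is that it was not resolved as an inhibitor, while compound 2 and compound 3 both sit at weak, micromolar-range inhibition.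

Compound 4, `O=C(N/N=C/c1cc(Br)c(O)c(Br)c1)Nc1ccc(Oc2ccnc3[nH]ccc23)c(F)c1`, is not yet measured. It differs from compound 1 in one place: 3,5-dibromo-4-hydroxyphenyl in place of 3-nitrophenyl on a carbon with a double bond to nitrogen. Going by the values given here, no measured pair gives a step of this kind, so the size of the step in this assay cannot be computed from the data. Given that every resolved value in the series is weak, the expectation is that compound 4 will move from the unresolved state of compound 1 into the same weak range as compound 2 and compound 3, with a real chance that it again returns no number. Compound 4 is therefore estimated at 12000 nM, within a range of 2500 nM to 60000 nM.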

Compound 4, half-maximal inhibitory concentration: "not active" (no number reported)
The entry for compound 4 holds no number, so the estimate cannot be set against anything.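

In this assay compound 1 gives "not active" (no number reported) and compound 4 gives "not active" (no number reported) so no step can be read between the two. The compounds shown leave open whether 3-nitrophenyl and 3,5-dibromo-4-hydroxyphenyl differ at all on the shared core in this assay as neither has a number. No supporting data bear on this result.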